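Azidomethyl at the carbonyl carbon: estimating compound 4

This account rests on a few compounds, and the source may have more. Where it says the series, first, only, none or still open, it means among the compounds named here.

Measured so far in a functional assay on HCT-116 cells (Homo sapiens) for inhibition, read by MTT assay, with a stated time of 48 h (on this read-out lower numbers stand for stronger inhibition and higher numbers for weaker inhibition), as read-out

- compound 1 `COCC(=O)N(Cc1ccc(OC)c(O)c1)c1cc(OC)c(OC)c(OC)c1` gives 230 nM
- compound 2 `C/C=C/C(=O)N(Cc1ccc(OC)c(N)c1)c1cc(OC)c(OC)c(OC)c1` gives 300 nM
- compound 3 `C/C=C/C=C/C(=O)N(Cc1ccc(OC)c(O)c1)c1cc(OC)c(OC)c(OC)c1` gives 180 nM

Compound 3 (180 nM) lies within the scatter of compound 1 and of compound 2, so these three values cannot be ranked. The next structure is compound 4 `COc1ccc(CN(C(=O)CN=[N+]=[N-])c2cc(OC)c(OC)c(OC)c2)cc1O`, with azidomethyl in place of penta-1,3-dien-1-yl on a carbonyl carbon. Within the data shown here, one measured step bears on this place: a 1.3-fold lower number from compound 1 to compound 3 (0.11 log units; within the scatter) (methoxymethyl replaced by penta-1,3-dien-1-yl on the same carbonyl carbon). Among the measured compounds shown here, compound 2 differs from compound 3 in more than one place and gives no single-change step. For the measured compounds named here, no measured compound carries azidomethyl, so the range stays wide. In this assay no step beyond the scatter is expected, and no direction can be called. The estimated step is a 1.1-fold higher number from compound 3 to compound 4 (0.05 log units; within the scatter) at the middle of the range. For compound 4 the expected value is 200 nM (estimated range 70 nM to 600 nM).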

Compound 4, half-maximal inhibitory concentration: 410 nM
Beside the measured number, compound 4's estimate is 2.1-fold (0.31 log units) below it; the measured number falls inside the stated range.
By their numbers in this assay, from the lowest: compounds 3, 1, 2 and 4 (each within the scatter of the next, the first and the last beyond it).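

In this assay the substituent on a carbonyl carbon whose other neighbour is the amide-type nitrogen gives its first step beyond the scatter, a 2.3-fold higher number from compound 3 to compound 4 (0.36 log units; beyond the scatter), with azidomethyl in place of penta-1,3-dien-1-yl. The earlier step at this place, a 1.3-fold lower number from compound 1 to compound 3 (0.11 log units; within the scatter), did not show this, and the new step remains modest. The change from methoxy to azido on the saturated chain carbon bound to the carbonyl carbon stays within the scatter, a 1.8-fold higher number from compound 1 to compound 4 (0.25 log units; within the scatter), so compound 1 cannot be separated from either compound 3 or compound 4.

No measured evidence bears on what lies behind the step. The compounds shown leave open whether an amine, a carboxylic acid or a longer saturated chain in place of azidomethyl on the carbonyl carbon would move the number further in either direction.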